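This account rests on a few compounds, and the source may have more. Where it says the series, first, only, none or still open, it means among the compounds named here.

Measured so far in a functional assay, with a stated time of 30 min; a higher number here means a weaker inhibitor, a lower number a stronger inhibitor:
- Compound 1 `COC(=O)c1c(C(=O)c2c(O)cc(C)cc2OC)c(OC)cc(O)c1[S@@+](C)[O-]`: > 100000 nM, a limit.
- Compound 2 `COC(=O)c1c(C(=O)c2c(O)cc(C)cc2OC)c(OC)cc(O)c1[S@+](C)[O-]`: > 100000 nM, a limit.

Compound 2 has no numerical value in this assay, only the limit shown. Compound 3 `COC(=O)c1c(C(=O)c2c(O)cc(C)cc2OC)c(OC)cc(O)c1[S+](C)[O-]` differs from compound 2 as follows: the two compounds have the same atoms and bonds; at least one stereo element is drawn with a configuration in one of them and without one in the other: 1 of 1 stereo elements differ; a stereocentre at a sulfur is drawn S in compound 2 and without a configuration in compound 3. No group leaves or enters.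

Among the compounds with values here, the only measured step that bears on this change is a step that the two limits leave unreadable from compound 1 to compound 2. Its size cannot be read, and the evidence consists of the limit of > 100000 nM in this assay, at which 2 of the 2 values shown sit, and (the fact that compounds 1 and 2 differ only in the configuration as drawn). Neither drawn configuration gives a number, so no step beyond the scatter is expected in this assay, and no direction can be assigned. The expected step is a step that the limit leaves unreadable from compound 2 to compound 3. A further limit is the likeliest report for compound 3. If a number is obtained, the estimate for compound 3 is 150000 nM, with an expected range of 80000 nM to 400000 nM.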

Compound 3, half-maximal inhibitory concentration: > 100000 nM
Compound 3: only a limit was reported; the forecaster's own chance of this, stated with the estimate: 90%; the middle value is on the limit's open side.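

In this assay compound 3 gives > 100000 nM, which is a limit. No step can be read among compound 1, compound 2 and compound 3, since all three results are limits. The compounds shown leave open whether the configuration at the sulfur affects inhibition in this assay.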